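Adding an Amino Group to Two Inactive Nucleoside Analogues

A few compounds are considered here, and "the series" means these few. Any claim that something is new, unique, unknown or untested is made for them only; others in the source may bear on it.

Two measured compounds share one core and differ in a single group. Compound 1 `C=C1[C@H](CO)OC[C@@H]1n1cnc2c(N)ncnc21` carries an amino group on an aromatic carbon of that core. In a functional assay for cytotoxicity (a lower number here means a stronger inhibitor, a higher number a weaker inhibitor), compound 1 gives > 100 ug/mL, which is a limit of the assay and not a measured number. Compound 2 `C=C1[C@H](CO)OC[C@@H]1n1cnc2c(O)ncnc21` has a hydroxy in place of that amino. In this assay compound 2 gives > 100 ug/mL, again a limit rather than a number. For the measured compounds named here, compound 2 therefore stands only at a limit, and the one other value shown is a limit as well. The step that the two limits leave unreadable from compound 1 to compound 2 cannot be sized: what is known is that (the limit of > 100 ug/mL in this assay, at which 2 of the 2 values shown sit).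

Compound 3 `C=C1[C@H](CO)OC[C@@H]1n1cnc2c(O)nc(N)nc21` is not yet measured. Its change from compound 2 is amino in place of hydrogen on an aromatic carbon. Going by the values given here, the only measured step that bears on this change is the unreadable one just described, so no direction beyond the scatter can be drawn from it. Compound 3 is expected to remain at the limit, so the step that the limit leaves unreadable from compound 2 to compound 3 is estimated as essentially none. For compound 3 the expected value in this assay is 150 ug/mL, with a range from 50 ug/mL to 500 ug/mL.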

Compound 3, half-maximal inhibitory concentration: > 100 ug/mL
Compound 3: no number, only a limit; the forecaster's own chance of this, stated with the estimate: 85%; the middle value lies beyond the limit too.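

In this assay compound 3 gives > 100 ug/mL, which is a limit of the assay and not a measured number, so the step from compound 2 to compound 3 cannot be read: the limit of > 100 ug/mL in this assay, at which 3 of the 3 values shown sit.

The compounds shown leave open how strong any of the three is, and whether the amino and hydroxy changes on the shared core make any difference in this assay.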